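A few compounds are considered here, and "the series" means these few. Any claim that something is new, unique, unknown or untested is made for them only; others in the source may bear on it.

Two compounds have so far been measured in a functional assay on CAKI-1 cells (Homo sapiens) for cytotoxicity, read by sulforhodamine B assay, with a stated time of 48 h, tested at 10 uM; on this read-out lower numbers stand for a stronger effect and higher numbers for a weaker effect at the one concentration tested:

Compound 1 `COc1ccc(-c2cc(/C=C/C(=O)c3ccc(N)cc3)[nH]n2)cc1` gives 3%.
Compound 2 `COc1cc(-c2cc(/C=C/C(=O)c3ccc(Cl)c(Cl)c3)[nH]n2)cc(OC)c1OC` gives 62%.

Compound 2 stands at the highest of the two measured numbers, which on this read-out means the weaker effect at the single concentration tested. Its nearest neighbour, compound 1, lies far lower, a gap well beyond the usual scatter of such measurements. Within the data shown here, the two compounds differ in more than one place, so no single step between them is available; only their two values can be compared.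

Compound 3 `COc1ccc(C(=O)/C=C/c2cc(-c3cc(OC)c(OC)c(OC)c3)n[nH]2)cc1OC` is the next compound to be measured in this assay. It differs from compound 2 in one place: 3,4-dimethoxyphenyl in place of 3,4-dichlorophenyl on a carbonyl carbon. Among the measured compounds shown here, no measured pair with a change in only one place exists here, so the size of this step cannot be read from earlier data. For compound 3 an estimate of 40% is expected, within a range from 10% to 75%, corresponding to an expected step of a number 22 percentage points lower from compound 2 to compound 3 (beyond the scatter), a moderate drop toward a stronger effect, though the wide range shows how uncertain this expectation is.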

Compound 3, a percentage reported as activity, at one concentration (the size of the read-out at that concentration, not a potency): -33%
Compound 3: the middle estimate sits 73 percentage points above what was measured, and the stated range ends above it.
By their numbers in this assay, from the lowest: compound 3; then compound 1; then compound 2.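

In this assay, among these compounds, the group on the carbonyl carbon turns out to carry a great deal of weight: putting 3,4-dimethoxyphenyl in place of 3,4-dichlorophenyl gives a number 95 percentage points lower from compound 2 to compound 3 (beyond the scatter) and is the first change at a single place that can be read in this small set. The rest of the structure is the same in this pair, so the whole step belongs to this one exchange, and compound 3 reaches -33% as a value below zero, on the stronger side of this read-out. Nothing available here bears on why the two groups give such different results.

From the compounds shown here alone, with only these two groups compared on the carbonyl carbon, it remains open how a plain phenyl, a phenyl carrying a single methoxy group or one carrying two hydroxyl groups would behave, and so whether the methoxy groups, the chlorines or both set the size of this step. Going by these compounds, compound 1 differs from each of the other two compounds in more than one place, so its steps to them cannot be read, and whether the same exchange would have a similar effect on its core also stays unknown.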